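Benzyloxy in place of oxan-4-yl at the amide carbonyl

The compounds below may be only part of what the source reports. "The series", "measured", "known", "first", "only" and "open" are said of these compounds alone.

Of the compounds shown here, two have numbers so far. Compound 1 `Cc1cc(C(=O)Nc2ccccn2)nn1Cc1cc(Cl)ccc1OCc1ccccc1` gives 126 nM in an assay on CHO-K1 cells for displacement of a labelled ligand from prostaglandin E2 receptor EP1 subtype (Homo sapiens); on this read-out lower numbers stand for stronger inhibition and higher numbers for weaker inhibition. Compound 2 `Cc1cc(NC(=O)C2CCOCC2)nn1Cc1cc(Cl)ccc1OCc1ccccc1` gives 63.1 nM in this assay; the step of a 2.0-fold lower number from compound 1 to compound 2 (0.30 log units; within the scatter) is within the scatter, so no order between the two can be read, and compound 2 has one of two numbers that sit within the scatter of each other.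

Compound 3 `Cc1cc(NC(=O)OCc2ccccc2)nn1Cc1cc(Cl)ccc1OCc1ccccc1` is not yet measured. It differs from compound 2 by benzyloxy in place of oxan-4-yl on a carbonyl carbon. Among the measured compounds shown here, only one measured step touches this part of the molecule: from compound 1 to compound 2 the whole arrangement around the amide was rebuilt, and even that change stayed within the scatter. For the measured compounds named here, no measured step exchanges oxan-4-yl for benzyloxy on the carbonyl carbon, so nothing in the data points to a change of number in either direction.

The expected step of a 1.1-fold lower number from compound 2 to compound 3 (0.02 log units; within the scatter) is therefore none beyond the scatter. Compound 3 is estimated at 60 nM in this assay, with a range from 20 nM to 200 nM.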

Compound 3, half-maximal inhibitory concentration: 79.4 nM
Compound 3: the middle estimate sits 1.3-fold (0.12 log units) below what was measured; low and high end bracket the measured number.
By their numbers in this assay, from the lowest: compounds 2, 3 and 1 (each within the scatter of the next).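

In this assay, benzyloxy in place of oxan-4-yl on the carbonyl carbon gives a 1.3-fold higher number from compound 2 to compound 3 (0.10 log units; within the scatter), so this place accepts an aromatic ring of carbon only as well as a non-aromatic ring with a hetero atom, with no difference that can be read. The comparison with the reversed amide arrangement of compound 1 gives the same picture, with a 1.6-fold lower number from compound 1 to compound 3 (0.20 log units; within the scatter), and all three compounds now stand within the scatter of each other, so none of the three groups can be ranked over another. No further data accompany these numbers that would explain this lack of a readable difference.

The compounds shown leave open whether any group at this carbonyl carbon can move the number beyond the scatter, for instance a charged piperidin-4-yl amine, a carboxylic acid at the end of a longer chain, or a plain methyl. Also open, going by these compounds, is whether the tolerance seen here for oxan-4-yl and benzyloxy would persist if the chlorine or the benzyloxy group on the shared core were replaced.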